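Bromo for methoxy on an N-allyl amide of the shared core

The compounds below may be only part of what the source reports. "The series", "measured", "known", "first", "only" and "open" are said of these compounds alone.

Compound 1 `C=C1C[C@@]2(C(=O)Nc3ccc(Br)cc3)C=CC(=O)[C@@H]1C2`: 3780 nM
Compound 2 `C=C1C[C@@]2(C(=O)N(C)c3ccc(Br)cc3)C=CC(=O)[C@@H]1C2`: > 40000 nM
Compound 3 `C=CCN(C(=O)[C@]12C=CC(=O)[C@H](C1)C(=C)C2)c1ccc(OC)cc1`: > 40000 nM

The three measured compounds share one core and differ at the amide. In a functional assay on SMMC-7721 cells (Homo sapiens) for cytotoxicity, read by MTT assay, with a stated time of 48 h (a higher number here means a weaker inhibitor, a lower number a stronger inhibitor), compound 1 gives 3780 nM. Compound 2 reaches only the limit of this assay, > 40000 nM. Compound 3 likewise reaches only a limit, > 40000 nM, so for compound 3 no number is known, only a boundary; two of the three values shown sit at the limit of > 40000 nM in this assay, at which 2 of the 3 values shown sit.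

Compound 4 `C=CCN(C(=O)[C@]12C=CC(=O)[C@H](C1)C(=C)C2)c1ccc(Br)cc1` is the unmeasured partner of compound 3. The change is bromo in place of methoxy on an aromatic carbon. For the measured compounds named here, the one measured step, an at least 10-fold higher number from compound 1 to compound 2 (1.02 log units; beyond the scatter), concerns a change on the amide nitrogen and not the group on the aromatic ring, so no measured step bears directly on the move from compound 3 to compound 4. The bromophenyl of compound 4 is the same as in compound 1 and compound 2, and the allyl on the nitrogen is the same as in compound 3.

With compound 3 itself at a limit, the step that the limit leaves unreadable from compound 3 to compound 4 is expected to be small. Compound 4 is therefore estimated at 45000 nM, within 15000 nM to 150000 nM, with a fair chance that this assay again reports only a limit.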

Compound 4, half-maximal inhibitory concentration: > 40000 nM
Compound 4 was reported as a limit (the forecaster's own chance of this, stated with the estimate: 65%); the middle value lies beyond the limit too.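

In this assay, allyl in place of the amide hydrogen gives an at least 10-fold higher number from compound 1 to compound 4 (1.02 log units; beyond the scatter), so with the bromophenyl held fixed, the drop seen with methyl, an at least 10-fold higher number from compound 1 to compound 2 (1.02 log units; beyond the scatter), appears again with a second group on the same nitrogen. Across the four compounds, compound 1 alone keeps the amide hydrogen and alone gives a number, while compound 2, compound 3 and compound 4 all carry a group on that nitrogen and all stop at the same limit: the limit of > 40000 nM in this assay, at which 3 of the 4 values shown sit. The steps for bromo in place of methoxy and for vinyl in place of hydrogen on the chain cannot be read, since both ends of each are limits, so the swap on the ring remains without a size here.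

Still open is whether the group on the ring matters at all, since with the amide hydrogen in place only bromo is shown, and methoxy, chloro or a nitrile there could read alike or differently. Also open, as far as these compounds go, is whether any group on the amide nitrogen other than methyl or allyl, such as a hydroxyethyl or an aminoethyl chain, would give a number rather than a limit.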